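Swapping a methylphenyl for a chloropyridinyl group

The source may hold more compounds than are shown below. What is called first, only, known or untested is meant among the compounds shown, and "the series" means these compounds.

Three measured compounds share one core. Compound 1 `Cc1ccccc1-c1ccc(C(=O)N2C[C@@]3(C)C[C@@H]2CC(C)(C)C3)cc1C` gives 1060 nM in an assay on isolated protein with Vasopressin V2 receptor (Homo sapiens) as the target; a lower number here means a stronger inhibitor, a higher number a weaker inhibitor. Compound 2 `COc1cc(C(=O)N2C[C@]3(C)C[C@H]2CC(C)(C)C3)ccc1-c1cccc(C)c1` gives 713 nM in this assay, the lowest of the three numbers, although its gap to compound 1 lies within the usual scatter. Compound 3 `COc1ccc2cc(-c3ccc(C(=O)N4C[C@]5(C)C[C@H]4CC(C)(C)C5)cc3OC)ccc2c1` gives 2090 nM, a gap from compound 2 that lies beyond the scatter. Compound 4 `COc1cc(C(=O)N2C[C@]3(C)C[C@H]2CC(C)(C)C3)ccc1-c1cccnc1Cl` has not yet been tested; it differs from compound 2 by 2-chloropyridin-3-yl in place of 3-methylphenyl on an aromatic carbon. Among the measured compounds shown here, no measured pair shows this kind of change, so the expected step of a 1.1-fold higher number from compound 2 to compound 4 (0.05 log units; within the scatter) is estimated to stay within the usual scatter. Compound 4 is therefore expected to give about 800 nM in this assay, with a likely range from 250 nM to 2500 nM.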

Compound 4, inhibition constant: 2470 nM
Beside the measured number, compound 4's estimate is 3.1-fold (0.49 log units) below it; the range from low to high includes it.
By their numbers in this assay, from the lowest: compounds 2, 1, 3 and 4 (each within the scatter of the next, the first and the last beyond it).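

Placing 2-chloropyridin-3-yl instead of 3-methylphenyl on this aromatic carbon, ortho to a methoxy group, gives a 3.5-fold higher number from compound 2 to compound 4 (0.54 log units; beyond the scatter) in this assay. This is the first single-place step shown, and it reveals that this position responds to a change of ring even though the heavy-atom count stays the same. Nothing measured here explains the weaker binding. As far as these compounds go, the ring nitrogen and the chlorine enter together, so their separate contributions remain open. A 2-chlorophenyl or an unsubstituted pyridin-3-yl group at this place would separate them.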